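Removing the bromoacryl amide from the anilide: compound 4

This account rests on a few compounds, and the source may have more. Where it says the series, first, only, none or still open, it means among the compounds named here.

compound 1 `Nc1cccc(/C=C2\SC(=O)N(Cc3cccc(F)c3)C2=O)c1` gives > 250000 nM, a limit of the assay rather than a number
compound 2 `Nc1cccc(/C=C2\SC(=O)N(Cc3ccc(F)cc3)C2=O)c1` gives 140000 nM
compound 3 `C=C(Br)C(=O)Nc1cccc(/C=C2\SC(=O)N(Cc3ccccc3)C2=O)c1` gives 810 nM

Compound 3 holds the lowest number of the two numbers recorded in a functional assay on FM3A cells (Mus musculus) for cytotoxicity, read by cell counting, with a stated time of 2 days; on this read-out higher numbers stand for weaker inhibition and lower numbers for stronger inhibition; the nearest, compound 2, sits a long way higher, beyond the scatter. The step of an at least 1.7-fold lower number from compound 1 to compound 2 (0.25 log units; that floor lies within the scatter) is small and its floor lies within the scatter, so the two fluorobenzyl compounds with a free amino group look alike. Compound 1 is recorded only as a limit, (the limit of > 250000 nM in this assay, at which 1 of the 3 values shown sits).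

Compound 4 `Nc1cccc(/C=C2\SC(=O)N(Cc3ccccc3)C2=O)c1` differs from compound 3 as hydrogen in place of (1-bromoethenyl)carbonyl on a nitrogen on an aromatic ring. Among the compounds with values here, no measured pair carries this exact change, but compound 1 and compound 2 both carry the amino group and both sit far above compound 3, while compound 3 alone carries the (1-bromoethenyl)carbonyl group. The step from compound 3 to compound 4 is therefore expected to be a large rise in this assay, a 190-fold higher number from compound 3 to compound 4 (2.27 log units; beyond the scatter), back into the range of compound 2. Compound 4 is expected to give about 150000 nM, within 30000 nM to 400000 nM, with a fair chance that only a limit is reported.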

Compound 4, half-maximal inhibitory concentration: > 250000 nM
Compound 4: a limit, no number; the forecaster's own chance of this, stated with the estimate: 35%; middle value at least 1.6-fold (0.22 log units) from the limit.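

Compound 4 is recorded in this assay only as a limit, not a number: the limit of > 250000 nM in this assay, at which 2 of the 4 values shown sit.

Hydrogen in place of (1-bromoethenyl)carbonyl on a nitrogen on an aromatic ring gives an at least 300-fold higher number from compound 3 to compound 4 (2.48 log units; beyond the scatter); this is the first step in the series that isolates this group, and the low number of compound 3 does not survive its loss. Among the free amino compounds, hydrogen in place of fluoro gives an at least 1.7-fold higher number from compound 2 to compound 4 (0.25 log units; that floor lies within the scatter), so this change shows no readable effect, and the two limits leave the step from compound 1 to compound 4 unreadable.

Going by these compounds, whether a plain acetyl or an acryloyl without the bromine on this nitrogen would keep the low number remains open. Also open, on these data alone, is whether a fluoro on the benzyl changes the number when the (1-bromoethenyl)carbonyl group is present.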